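A Methyl Branch and Tolerated Concentration on MT4 Cells

A few compounds are considered here, and "the series" means these few. Any claim that something is new, unique, unknown or untested is made for them only; others in the source may bear on it.

Three compounds have been examined in a functional assay on MT4 cells (Homo sapiens) for cytotoxicity; a higher number here means that more compound is tolerated, a lower number that less compound is tolerated. Compound 1 `O=c1cc(Cc2c(F)cccc2F)nc(SC2CCCC2)[nH]1` gives only a limit of the assay, namely > 200000 nM. Compound 2 `CC(C)Sc1nc(O)cc(C(C)c2c(Cl)cccc2Cl)n1` gives 117000 nM in this assay. Compound 3 `CCC(c1cc(O)nc(SC(C)C)n1)c1c(Cl)cccc1Cl` likewise gives only a limit of the assay, > 200000 nM. Compound 3 differs from compound 2 by methyl in place of hydrogen on a saturated chain carbon, two bonds along the chain from two aromatic carbons, and that change brought an at least 1.7-fold higher number from compound 2 to compound 3 (0.23 log units; that floor lies within the scatter). How compound 1 and compound 2 differ in their cores is not broken down here. What stands out across the measured set is the limit of > 200000 nM in this assay, at which 2 of the 3 values shown sit.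

Compound 4 `CC(c1cc(=O)[nH]c(SC2CCCC2)n1)c1c(F)cccc1F` is not yet measured. It differs from compound 1 by methyl in place of hydrogen on a saturated chain carbon bound to two aromatic carbons. Among the measured compounds shown here, this is the same kind of change as the one from compound 2 to compound 3, though not the same: there the carbon carrying the new methyl lay two bonds along the chain from two aromatic carbons, here it is bound to two aromatic carbons. For the measured compounds named here, compound 1 already sits at the limit of this assay, and the one measured step of this kind ran toward that limit rather than away from it. On that basis the step from compound 1 to compound 4 is expected to be a number no higher from compound 1 to compound 4 (the limit leaves the size open). Compound 4 is therefore estimated to give about 200000 nM in this assay, most likely reported again only as a limit, within an expected range from 100000 nM to 400000 nM.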

Compound 4, half-maximal cytotoxic concentration: > 200000 nM
Compound 4: only a limit was reported (the forecaster's own chance of this, stated with the estimate: 70%); the middle value sits exactly at the limit.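

Among the compounds shown here, compound 1 and compound 4 both give only a limit in this assay, so no step between them can be read. The measured set now gathers at a single point: the limit of > 200000 nM in this assay, at which 3 of the 4 values shown sit. The compounds shown leave open where the numbers of compound 1, compound 3 and compound 4 lie beyond that limit, and whether methyl in place of hydrogen on this carbon changes the number at all.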